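This account rests on a few compounds, and the source may have more. Where it says the series, first, only, none or still open, it means among the compounds named here.

Measured so far:
compound 1, `C[C@H](N)C(=O)NS(=O)(=O)OC[C@H]1OC[C@@H](n2cnc3c(N)ncnc32)[C@H](O)[C@@H]1O`, with 68% in a functional assay on PBMC cells (Homo sapiens) for inhibition, tested at 0.5 uM; a higher number here means more inhibition at the concentration tested (going by the name of the read-out), a lower number less inhibition;
compound 2, `CSCC[C@H](N)C(=O)NS(=O)(=O)OC[C@H]1O[C@@H](n2cnc3c(N)ncnc32)[C@H](O)[C@@H]1O`, with 28.4% in this assay.

Of the two numbers, compound 2 stands lowest: its value sits well below that of compound 1, and the gap between them lies beyond the usual scatter. For the measured compounds named here, no single-point step joins these two, so nothing more than the two values themselves can be read from the pair.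

The next compound, compound 3, is `Nc1ncnc2c1ncn2[C@@H]1O[C@H](COS(=O)(=O)NC(=O)[C@@H]2CCCN2)[C@@H](O)[C@H]1O`. It differs from compound 2 in one place:
pyrrolidin-2-yl in place of 1-amino-3-(methylsulfanyl)propyl on a carbonyl carbon
The change sits on the carbonyl carbon whose other neighbour is the amide-type nitrogen.

Going by the values given here, with only two measured compounds and no counted step to lean on, the size of the move from compound 2 to compound 3 in this assay is uncertain. The expectation is a modest rise, a number 11.6 percentage points higher from compound 2 to compound 3 (beyond the scatter), of a size that may not clear the scatter. Compound 3 is therefore estimated at 40% in this assay, within a range from 15% to 65%.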

Compound 3, a percentage reported as inhibition, at one concentration (the size of the read-out at that concentration, not a potency): 18.6%
Compound 3: middle estimate off by 21.4 percentage points, on the high side; the range from low to high includes it.
By their numbers in this assay, from the lowest: compounds 3 and 2 (each within the scatter of the next); then compound 1.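

For the compounds shown here, the exchange of 1-amino-3-(methylsulfanyl)propyl for pyrrolidin-2-yl on the carbonyl carbon is the first change at this position that can be read as a single step, and in this assay it amounts to a number 9.8 percentage points lower from compound 2 to compound 3 (within the scatter) on the shared core. In this one pair, then, an open chain carrying sulfur and a five-membered non-aromatic ring holding one hetero atom cannot be told apart at this place, so the read-out gives no sign that either the chain or the ring matters here. Nothing measured alongside this read-out bears on the step, so the pair offers a size and no explanation.

The compounds shown leave open how this position would respond to a larger departure, such as piperidin-2-yl, a pyrrolidin-2-yl carrying a hydroxyl group, or a longer chain ending in a carboxylic acid. They also leave open whether the same exchange of pyrrolidin-2-yl for 1-amino-3-(methylsulfanyl)propyl would read alike on the core of compound 1.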